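The compounds below may be only part of what the source reports. "The series", "measured", "known", "first", "only" and "open" are said of these compounds alone.

Compound 1 `C=CC(=O)N1C(=O)CC(c2ccccc2Cl)Sc2ccccc21`: 91400 nM
Compound 2 `C=CC(=O)N1C(=O)CC(c2ccccc2C(F)(F)F)Sc2ccccc21`: 96400 nM

Both compounds were tested in a functional assay on HL-60 cells (Homo sapiens) for cytotoxicity, read by CCK-8 assay, with a stated time of 24 h; on this read-out lower numbers stand for stronger inhibition and higher numbers for weaker inhibition. Compound 1 stands together with compound 2 in the same range of weak cytotoxicity: the step of a 1.1-fold higher number from compound 1 to compound 2 (0.02 log units; within the scatter) lies within the scatter, so neither compound can be set above the other on these two numbers alone.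

Compound 3 `C=CC(=O)N1C(=O)CC(c2ccc(C#N)cc2)Sc2ccccc21` differs from compound 1 by 4-cyanophenyl in place of 2-chlorophenyl on a saturated ring carbon. Going by the values given here, the one measured step that bears on this change is a 1.1-fold higher number from compound 1 to compound 2 (0.02 log units; within the scatter), where exchanging the substituent on the phenyl ring of the shared core left the read-out unmoved. That step is only a partial guide, since in compound 3 the whole aryl group changes from 2-chlorophenyl to 4-cyanophenyl. On this evidence no step beyond the scatter is expected, and the estimate for compound 3 means a 1.1-fold higher number from compound 1 to compound 3 (0.04 log units; within the scatter). Compound 3 is therefore expected to give about 100000 nM in this assay, with a range from 40000 nM to 250000 nM.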

Compound 3, half-maximal inhibitory concentration: 115000 nM
Beside the measured number, compound 3's estimate is 1.2-fold (0.06 log units) below it; the measured number falls inside the stated range.
By their numbers in this assay, from the lowest: compounds 1, 2 and 3 (each within the scatter of the next).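

In this assay, exchanging the whole aryl group on this saturated ring carbon next to the ring sulfur gives a 1.3-fold higher number from compound 1 to compound 3 (0.10 log units; within the scatter) and so does not separate 4-cyanophenyl from 2-chlorophenyl. The earlier pair showed this only for trifluoromethyl in place of chloro, whereas compound 3 brings in a different aryl group carrying a nitrile, and compounds 1, 2 and 3 still stand each within the scatter of the next. No measurement shown here offers an explanation for this flat result.

All three compounds keep an aryl group at this carbon, so they leave open how an aliphatic amine or a carboxylic acid there would read. They also leave open whether a change at this position can move the number out of this weak range, and what replacing the vinylcarbonyl group with a saturated propanoyl group would do.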